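The compounds below may be only part of what the source reports. "The series", "measured", "known", "first", "only" and "open" are said of these compounds alone.

Compound 1 `COc1cc(-c2ccnc3cc(-c4ccc(C)cc4)nn23)cc(OC)c1OC` gives 21 nM in a functional assay on HeLa cells (Homo sapiens) for inhibition, read by CCK-8 assay, with a stated time of 48 h (on this read-out lower numbers stand for stronger inhibition and higher numbers for weaker inhibition), the lowest of the two numbers in hand. Within the data shown here, compound 3 `COc1cc(-c2ccnc3cc(-c4ccccc4)nn23)cc(OC)c1OC` gives 458 nM in this assay, and the step of a 22-fold higher number from compound 1 to compound 3 (1.34 log units; beyond the scatter) is the only change on that aromatic carbon. Compound 2 `COc1cc(-c2ccnc3cc(-c4cccc(C#N)c4)nn23)cc(OC)c1OC` sits at a limit, > 10000 nM, rather than at a number (the limit of > 10000 nM in this assay, at which 1 of the 3 values shown sits). The step of an at least 470-fold higher number from compound 1 to compound 2 (2.67 log units; beyond the scatter) changes both group and ring position at once and bears less directly. Compound 4 `COc1ccc(-c2cc3nccc(-c4cc(OC)c(OC)c(OC)c4)n3n2)cc1` differs from compound 1 by methoxy in place of methyl on an aromatic carbon. Because the step of a 22-fold higher number from compound 1 to compound 3 (1.34 log units; beyond the scatter) shows a large loss with hydrogen in place of methyl, compound 4 is expected to keep most of that potency, with a 1.9-fold higher number from compound 1 to compound 4 (0.28 log units; within the scatter) likely within the scatter. Compound 4 is estimated at 40 nM, range 10 nM to 300 nM.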

Compound 4, half-maximal inhibitory concentration: 373 nM
Beside the measured number, compound 4's estimate is 9.3-fold (0.97 log units) below it; measured number above the stated range.
By their numbers in this assay, from the lowest: compound 1; then compounds 4 and 3 (each within the scatter of the next). At a limit, above all of these: compound 2.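

Methoxy on this aromatic carbon, para to a large group, does not match methyl, with an 18-fold higher number from compound 1 to compound 4 (1.25 log units; beyond the scatter), while methoxy and hydrogen cannot be told apart, with a 1.2-fold lower number from compound 3 to compound 4 (0.09 log units; within the scatter). Of these groups at this place, only methyl gives the lower number, so the gain does not extend to methoxy. The step with an at least 26-fold lower number from compound 2 to compound 4 (1.42 log units; beyond the scatter) is only a bound, as compound 2 stands at a limit: the limit of > 10000 nM in this assay, at which 1 of the 4 values shown sits.

Open, from the compounds shown here alone, is whether ethyl, chlorine or an amine on this carbon would match methyl. Also open, going by these compounds, is whether the nitrile or its ring position sets the limit of compound 2.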